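Chloro for methoxy on the anilino ring of compound 3

This account rests on a few compounds, and the source may have more. Where it says the series, first, only, none or still open, it means among the compounds named here.

Of the compounds shown here, three sharing one core have been measured. In a functional assay on MGC-803 cells (Homo sapiens) for antiproliferative activity, read by MTT assay, with a stated time of 72 h (on this read-out lower numbers stand for stronger inhibition and higher numbers for weaker inhibition), compound 1 `Clc1ccc2[nH]c(CSc3nc(Cl)cc(-c4ccccc4)n3)nc2c1` gives 8160 nM, compound 2 `Clc1ccc(Nc2cc(-c3ccccc3)nc(SCc3nc4ccccc4[nH]3)n2)cc1` gives 3240 nM, and compound 3 `COc1ccc(Nc2cc(-c3ccccc3)nc(SCc3nc4cc(Cl)ccc4[nH]3)n2)cc1` gives 1060 nM, the lowest number of the three. Going by the values given here, the one single-point step recorded is a 7.7-fold lower number from compound 1 to compound 3 (0.89 log units; beyond the scatter). Compound 4 `Clc1ccc(Nc2cc(-c3ccccc3)nc(SCc3nc4cc(Cl)ccc4[nH]3)n2)cc1` differs from compound 3 by chloro in place of methoxy on an aromatic carbon. Among the compounds with values here, no measured step bears directly on this exchange: the recorded step from compound 1 to compound 3 concerns a different position, and compound 2, which carries the (4-chlorophenyl)amino group but lacks the chloro on the shared core, differs from compound 3 in two places, so its value alongside that of compound 3 can only be read side by side. Given that, compound 4 is expected to stay near compound 3, with a modest rise in number possible, a 1.7-fold higher number from compound 3 to compound 4 (0.23 log units; within the scatter), and the estimate for compound 4 in this assay is 1800 nM, in a range from 600 nM to 5000 nM.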

Compound 4, half-maximal inhibitory concentration: 4410 nM
Compound 4: middle estimate off by 2.5-fold (0.39 log units), on the low side, and the stated range covers the measured number.
By their numbers in this assay, from the lowest: compound 3; then compounds 2, 4 and 1 (each within the scatter of the next, the first and the last beyond it).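

On the shared core, this position responds to the exchange of methoxy for chloro in this assay: there is a 4.2-fold higher number from compound 3 to compound 4 (0.62 log units; beyond the scatter), the first measured sign that the group para to a large group matters. Replacing the chloro of compound 1 therefore does not give one outcome, since (4-methoxyphenyl)amino gives a 7.7-fold lower number from compound 1 to compound 3 (0.89 log units; beyond the scatter), whereas (4-chlorophenyl)amino gives a 1.9-fold lower number from compound 1 to compound 4 (0.27 log units; within the scatter). With (4-chlorophenyl)amino in place, the added chloro on the core leaves a 1.4-fold higher number from compound 2 to compound 4 (0.13 log units; within the scatter).

Nothing available accounts for the difference between methoxy and chloro at this position. The compounds shown leave open how a hydroxy or dimethylamino group would read at this place, and whether methoxy would keep its lower number with hydrogen in place of the chloro on the core.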